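Trimethoxyphenyl hydrazone variant of a weak inhibitor series

The source may hold more compounds than are shown below. What is called first, only, known or untested is meant among the compounds shown, and "the series" means these compounds.

Going by the values given here, compound 1 `Cc1nc(N(C)C(=O)NC(=O)c2c(F)cccc2F)sc1C(=O)N/N=C/c1ccccc1` is the only member with a number in a functional assay on HepG2 cells (Homo sapiens) for inhibition, read by MTT assay, with a stated time of 72 h; a lower number here means a stronger inhibitor, a higher number a weaker inhibitor: compound 1 gives 54.3 ug/mL. Compound 2 `Cc1nc(N(C)C(=O)NC(=O)c2c(F)cccc2F)sc1C(=O)N/N=C/c1ccc(Cl)cc1` returns only a limit in this assay, where compound 2 gives > 100 ug/mL. That value is a limit of the assay (the limit of > 100 ug/mL in this assay, at which 1 of the 2 values shown sits). Among the compounds with values here, the single measured step, an at least 1.8-fold higher number from compound 1 to compound 2 (0.26 log units; that floor lies within the scatter), is chloro in place of hydrogen on an aromatic carbon, and its floor lies within the scatter, so it settles little. Compound 3 `COc1cc(/C=N/NC(=O)c2sc(N(C)C(=O)NC(=O)c3c(F)cccc3F)nc2C)cc(OC)c1OC` differs from compound 2 by 3,4,5-trimethoxyphenyl in place of 4-chlorophenyl on a carbon with a double bond to nitrogen. Within the data shown here, no measured pair exchanges the aromatic substituent in this way, so the chloro step is the only neighbour and does not bear directly on the trimethoxy exchange. Compound 2 starts at the limit, so the step of an at least 1.2-fold lower number from compound 2 to compound 3 (0.09 log units; that floor lies within the scatter) is expected to be none beyond the scatter, with a fair chance of another limit. Compound 3 is estimated at 80 ug/mL in this assay, with a range from 25 ug/mL to 250 ug/mL.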

Compound 3, half-maximal inhibitory concentration: > 100 ug/mL
Compound 3: only a limit was reported (the forecaster's own chance of this, stated with the estimate: 50%); middle value at least 1.2-fold (0.09 log units) away from the limit.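

In this assay compound 3 gives > 100 ug/mL, which is a limit of the assay and not a number. With 3,4,5-trimethoxyphenyl on the carbon with a double bond to nitrogen, a second substituted phenyl ring now sits at this limit, and the record against phenyl is an at least 1.8-fold higher number from compound 1 to compound 3 (0.26 log units; that floor lies within the scatter), so neither exchange is shown to go beyond the scatter. The step from compound 2 to compound 3 cannot be read, because both values sit at the same limit: the limit of > 100 ug/mL in this assay, at which 2 of the 3 values shown sit.

Going by these compounds, the true size of either exchange remains open, since neither substituted compound has a readable number. Also open, on these data alone, is how a dimethylamino group or a carboxylic acid on the phenyl ring would read against compound 1 at 54.3 ug/mL.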